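Methyl on the lactone ring: cytotoxicity in the coumarin-indole series

The source may report more compounds than this note shows. Statements on the series, on what has been measured and on what is new or still open speak of the compounds shown alone.

Measured so far:
compound 1 `CC(=O)Oc1ccc2ccc(=O)oc2c1Cc1c(C)[nH]c2ccccc12`: 62000 nM
compound 2 `Cc1[nH]c2ccccc2c1Cc1c(OC(=O)CCCC(=O)O)ccc2ccc(=O)oc12`: 27000 nM

Going by the values given here, in an ADME assay on MT4 cells (Homo sapiens) for cytotoxicity, read by MTT assay, with a stated time of 96 h (on this read-out lower numbers stand for higher toxicity in this test and higher numbers for lower toxicity in this test), compound 2 gives 27000 nM, the lowest of the two numbers; compound 1 gives 62000 nM, and the one step recorded, a 2.3-fold lower number from compound 1 to compound 2 (0.36 log units; beyond the scatter), separates them. That step changes the ester chain, not the aromatic part of the shared core.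

Compound 3 `Cc1[nH]c2ccccc2c1Cc1c(OC(=O)CCCC(=O)O)ccc2c(C)cc(=O)oc12` differs from compound 2 by methyl in place of hydrogen on an aromatic carbon. Among the compounds with values here, no measured pair covers a change of this kind: the only step, from compound 1 to compound 2, concerns the acyl chain and so does not bear on a methyl on the ring. With nothing to go on but the size of the change, a step within the scatter is expected, no change at the digits printed from compound 2 to compound 3 (within the scatter). Compound 3 is estimated at 27000 nM in this assay, with a range of 12000 nM to 60000 nM.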

Compound 3, half-maximal cytotoxic concentration: 29000 nM
The estimate for compound 3 lay 1.1-fold (0.03 log units) below the measured number, and the stated range covers the measured number.
By their numbers in this assay, from the lowest: compounds 2 and 3 (each within the scatter of the next); then compound 1.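

In this assay, methyl in place of hydrogen on an aromatic carbon, opposite the ring oxygen, gives a 1.1-fold higher number from compound 2 to compound 3 (0.03 log units; within the scatter) and so leaves the number unchanged within the scatter. This is the first step shown on the aromatic part of the shared core, and it shows that this position accepts a methyl with the 2-carboxyethyl chain in place, whereas the chain step gives a 2.3-fold lower number from compound 1 to compound 2 (0.36 log units; beyond the scatter) and lies beyond the scatter. No supporting data bear on why the methyl leaves the number where it is.

Going by these compounds, whether the methyl has the same outcome with the shorter acyl chain of compound 1 remains open. Also open, on these data alone, is how an ethyl, a phenyl or an amine at this same position would affect the cytotoxicity number.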